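Ester in place of acid on the imidazole ether chain

The compounds below may be only part of what the source reports. "The series", "measured", "known", "first", "only" and "open" are said of these compounds alone.

Compound 1 `COc1ccc(COCC(Cn2ccnc2)OCCCCC(=O)O)cc1` carries a carboxy group on a saturated chain carbon, four bonds along the chain from an oxygen on a saturated carbon. Among the measured compounds shown here, in a functional assay on a cell-free system (plasma) for inhibition of Thromboxane-A synthase (Homo sapiens) (on this read-out higher numbers stand for weaker inhibition and lower numbers for stronger inhibition), compound 1 gives 730 nM; this is the lowest of the two numbers known here. For the measured compounds named here, its only measured neighbour is compound 2 `COc1ccc(COCC(Cn2ccnc2)OCCCCCCC(=O)O)cc1`, which in this assay gives 1890 nM; the step of a 2.6-fold higher number from compound 1 to compound 2 (0.41 log units; beyond the scatter) came from stretching the acid outward. Compound 3 `CCOC(=O)C(C)(C)CCCCOC(COCc1ccc(OC)cc1)Cn1ccnc1` differs from compound 1 in another way: 1-(ethoxycarbonyl)-1-methylethyl in place of carboxy on a saturated chain carbon, four bonds along the chain from an oxygen on a saturated carbon. Going by the values given here, no measured step covers an acid turned into an ester, so the change from compound 1 to compound 2 only hints that alterations at this end of the chain are felt. The loss of the hydrogen-bond donor and the larger group are therefore expected to weaken inhibition somewhat, with an uncertain size. Compound 3 is estimated to give 3000 nM, most likely between 700 nM and 13000 nM, which would mean a step of a 4.1-fold higher number from compound 1 to compound 3 (0.61 log units; beyond the scatter).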

Compound 3, half-maximal inhibitory concentration: 17600 nM
Compound 3: middle estimate off by 5.9-fold (0.77 log units), on the low side; measured number outside the range, above it.
By their numbers in this assay, from the lowest: compound 1; then compound 2; then compound 3.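

In this assay, the swap of carboxy for 1-(ethoxycarbonyl)-1-methylethyl on this chain end is a much bigger change than the lengthening seen earlier: it gives a 24-fold higher number from compound 1 to compound 3 (1.38 log units; beyond the scatter) and, measured against the longer acid, a 9.3-fold higher number from compound 2 to compound 3 (0.97 log units; beyond the scatter). Both compounds with a free carboxylic acid therefore give lower numbers than the ester compound 3, so inhibition at this position can be lost to a far greater extent than the step between the two acids alone suggested. Nothing available here explains why the number climbs so far.

The new group differs from carboxy in several ways at once, as it is an ethyl ester, has extra methyl groups and has more heavy atoms, and it has no hydrogen-bond donor, so these three compounds cannot show which of these features accounts for the rise. From the compounds shown here alone, a plain ethyl ester on the chain of compound 1, without the extra methyl groups, or a primary amide at the same place would help to separate these features, and whether the loss comes from the ester itself or from the branching remains open.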